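From Methoxy to Trifluoromethyl in a Flat Series

The source may hold more compounds than are shown below. What is called first, only, known or untested is meant among the compounds shown, and "the series" means these compounds.

Of the compounds shown here, three have so far been measured in an ADME assay on L6 cells (Rattus norvegicus) for cytotoxicity, read by resazurin assay, with a stated time of 72 h; a lower number here means a stronger inhibitor, a higher number a weaker inhibitor. Compound 1 (`NC(c1ccc(Cl)cc1)(c1cccnc1)c1ccccc1Cl`) gives 76000 nM, compound 2 (`Clc1ccc(C(c2ccc(Cl)cc2)c2cccnc2)cc1`) gives 84700 nM, and compound 3 (`COc1cccc(C(O)(c2ccc(Cl)cc2)c2cccnc2)c1`) gives 85600 nM. Compound 3 therefore stands level with the other two, its number lying within the usual scatter of both.

The next compound, compound 4 (`OC(c1ccc(Cl)cc1)(c1cccnc1)c1cccc(C(F)(F)F)c1`), carries trifluoromethyl in place of methoxy on an aromatic carbon, meta to a large group: trifluoromethyl in place of methoxy on an aromatic carbon. Within the data shown here, no measured pair differs in one place only, so the data offer no direct precedent for this change. Even so, the three structures differ from one another and their numbers remain within the scatter, which gives no reason to expect a large move in this assay. The expected change, a 1.2-fold lower number from compound 3 to compound 4 (0.09 log units; within the scatter), is none beyond the scatter. For compound 4 the estimated value is 70000 nM, with an expected range from 32000 nM to 125000 nM.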

Compound 4, half-maximal inhibitory concentration: 60400 nM
The estimate for compound 4 lay 1.2-fold (0.06 log units) above the measured number; the range from low to high includes it.
By their numbers in this assay, from the lowest: compounds 4, 1, 2 and 3 (each within the scatter of the next).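

In this assay, this exchange gives the series its first direct reading at this position, on an aromatic carbon meta to a large group: a 1.4-fold lower number from compound 3 to compound 4 (0.15 log units; within the scatter), with trifluoromethyl in place of methoxy. This step shows that, in this pair, the two groups cannot be told apart at this place, even though methoxy carries a hydrogen-bond acceptor and trifluoromethyl carries none. No evidence in hand bears on this result.

On these data alone, whether an amine, a carboxylic acid or a longer chain at the same place would move the number beyond the scatter remains open. A single step also leaves open whether trifluoromethyl in place of methoxy would read the same way at any other place on the shared core.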